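Alkyne series: chloro to hydrogen on the compound 2 core

A few compounds are considered here, and "the series" means these few. Any claim that something is new, unique, unknown or untested is made for them only; others in the source may bear on it.

Measured compounds in a functional assay on LS174T cells (Homo sapiens) for inhibition, with a stated time of 4 days, tested at 1 uM; a higher number here means a stronger effect of the compound at the concentration tested, a lower number a weaker effect:
compound 1 `Fc1cccc(F)c1C#Cc1ccc2nccc(Cl)c2c1`: 43.8%
compound 2 `Fc1cccc(F)c1C#Cc1ccc2c(Cl)ccnc2c1`: 23.1%
compound 3 `CNc1ncc(C#Cc2c(F)cccc2F)c2ccccc12`: 99.8%

Compound 2 holds the lowest number of the three in this assay. Its nearest neighbour is compound 1, which sits higher by a margin beyond the scatter; the furthest is compound 3, whose number lies far above, again beyond the scatter. Compounds 1 and 2 share the same substituents on differently arranged cores, so their gap is not a single-point step and is read only as two values.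

The unmeasured compound 4 `Fc1cccc(F)c1C#Cc1ccc2cccnc2c1` keeps the core of compound 2 and differs from it in one place: hydrogen in place of chloro on an aromatic carbon. Within the data shown here, no single-point step of this kind stands among the measured compounds, so the expected size rests on the low starting point of compound 2 alone. A small downward step or none beyond the scatter is expected, and compound 4 is estimated to follow the step of a number 8.1 percentage points lower from compound 2 to compound 4 (within the scatter). Compound 4 is therefore expected to give about 15%, with a range from 0% to 40%.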

Compound 4, a percentage reported as inhibition, at one concentration (the size of the read-out at that concentration, not a potency): 90.7%
The estimate for compound 4 lay 75.7 percentage points below the measured number; the whole stated range lies below it.
By their numbers in this assay, from the lowest: compound 2; then compound 1; then compounds 4 and 3 (each within the scatter of the next).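

In this assay, among these compounds, the change from chloro to hydrogen on the aromatic carbon opposite the ring nitrogen gives the first single-point step, and it is large: a number 67.6 percentage points higher from compound 2 to compound 4 (beyond the scatter). This position on the core of compound 2 is therefore far from silent, and the low read-out of compound 2 depends on the chloro it carries there. Nothing available on the compounds accounts for the size of this step.

On these data alone, only two substituents at this position can be compared, so it remains open whether the read-out tracks the loss of chloro alone or would also hold with a methoxy, nitrile or methyl group there. As far as these compounds go, whether the same change on the core of compound 1 would give a step of similar size also remains open.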